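Extending a phenoxyalkyl chain on two benzofuran amidine cores

The source may report more compounds than this note shows. Statements on the series, on what has been measured and on what is new or still open speak of the compounds shown alone.

Compound 1 `CC(C)NC(=N)c1ccc2oc(-c3cccc(OCCCCCOc4ccccc4)c3)cc2c1` gives 10100 nM in an ADME assay on L6 cells (Rattus norvegicus) for cytotoxicity, read by resazurin assay, with a stated time of 70 h (on this read-out lower numbers stand for stronger inhibition and higher numbers for weaker inhibition), and compound 2 `CC(C)NC(=N)c1ccc2oc(-c3cccc(OCCCCCCOc4ccccc4)c3)cc2c1` gives 7400 nM. The step of a 1.4-fold lower number from compound 1 to compound 2 (0.14 log units; within the scatter) goes with the change (phenoxymethyl in place of phenoxy on a saturated chain carbon, five bonds along the chain from an oxygen on an aromatic ring). Compound 3 `N=C(N)c1ccc2cc(-c3ccc(OCCCCOc4ccccc4)cc3)oc2c1` has a different core; the difference between the two cores is not broken down here. In this assay compound 3 gives 14100 nM. Compound 4 `N=C(N)c1ccc2cc(-c3ccc(OCCCCCOc4ccccc4)cc3)oc2c1` has not been measured. It differs from compound 3 by phenoxymethyl in place of phenoxy on a saturated chain carbon, four bonds along the chain from an oxygen on an aromatic ring, which is the same kind of change as that from compound 1 to compound 2, though here the place is four bonds along the chain from an oxygen on an aromatic ring rather than five. Because the earlier step of a 1.4-fold lower number from compound 1 to compound 2 (0.14 log units; within the scatter) stayed within the scatter, a similarly small step a 1.4-fold lower number from compound 3 to compound 4 (0.15 log units; within the scatter) is expected. Compound 4 is therefore estimated at 10000 nM, with a range from 5000 nM to 20000 nM.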

Compound 4, half-maximal inhibitory concentration: 9000 nM
Beside the measured number, compound 4's estimate is 1.1-fold (0.05 log units) above it; the measured number falls inside the stated range.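

In this assay, phenoxymethyl in place of phenoxy on a saturated chain carbon, four bonds along the chain from an oxygen on an aromatic ring, gives a 1.6-fold lower number from compound 3 to compound 4 (0.19 log units; within the scatter). Set beside the earlier step, the change reads the same on both cores: the same change on two cores in this assay, a 1.4-fold lower number (0.14 log units; within the scatter) from compound 1 to compound 2 and a 1.6-fold lower number (0.19 log units; within the scatter) from compound 3 to compound 4, 1.1-fold (0.06 log units) apart, within the scatter of two such steps This shows that the step stayed small on these two cores, but with both steps inside the scatter it shows no real effect of the change on either core, and two pairs say nothing about a further core.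

Still open, from the compounds shown here alone, is what a longer chain, or an amine or a carboxylic acid in place of the phenoxy group, would give in this assay. Going by these compounds, what the difference between the two cores does on its own also stays open.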